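The source may report more compounds than this note shows. Statements on the series, on what has been measured and on what is new or still open speak of the compounds shown alone.

Compound 2 `CNC[C@@H]1CCN(c2cc3c(cc2F)c(=O)c(C(=O)O)cn3Cc2ccc(-n3cccn3)cc2)C1` sits at the edge of what an assay on isolated protein for inhibition of DNA topoisomerase 1 (Homo sapiens), with a stated time of 15 min (a higher number here means a weaker inhibitor, a lower number a stronger inhibitor), can resolve. In this assay compound 2 gives > 200000 nM, which is a limit of the assay and not a number. Its neighbours do give numbers: compound 3 `CNC[C@@H]1CCN(c2cc3c(cc2F)c(=O)c(C(=O)O)cn3Cc2ccc(-c3ccccc3)cc2)C1` gives 168000 nM, and compound 1 `CN[C@@H]1CCN(c2cc3c(cc2F)c(=O)c(C(=O)O)cn3Cc2ccc(-c3ccccc3)cc2)C1` gives 34800 nM. The step of an at least 1.1-fold lower number from compound 2 to compound 3 (0.07 log units; that floor lies within the scatter) cannot be read as a change, while the step of a 4.8-fold higher number from compound 1 to compound 3 (0.68 log units; beyond the scatter) shows that moving the methylamino group out by one carbon weakened inhibition in this assay.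

Compound 4 `NC[C@@H]1CCN(c2cc3c(cc2F)c(=O)c(C(=O)O)cn3Cc2ccc(-n3cccn3)cc2)C1` differs from compound 2 only in hydrogen in place of methyl on an amine nitrogen. Neither measured step touches this nitrogen substituent, so the size of its effect can only be guessed. Both measured steps were small or modest, and compound 2 already stands at the limit (the limit of > 200000 nM in this assay, at which 1 of the 3 values shown sits). The step from compound 2 to compound 4 is therefore expected to be small, a number no higher from compound 2 to compound 4 (the limit leaves the size open), in either direction. Compound 4 is estimated at 200000 nM in this assay, between 60000 nM and 600000 nM, with a good chance that this assay again reports only a limit.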

Compound 4, half-maximal inhibitory concentration: 91600 nM
The estimate for compound 4 lay 2.2-fold (0.34 log units) above the measured number, within the range that was stated.
By their numbers in this assay, from the lowest: compound 1; then compounds 4 and 3 (each within the scatter of the next). At a limit, above all of these: compound 2.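

Hydrogen in place of methyl on this amine nitrogen is the first change among the compounds shown to touch the nitrogen substituent, and it gives an at least 2.1-fold lower number from compound 2 to compound 4 (0.33 log units; beyond the scatter). With the 1H-pyrazol-1-yl group held in place, the aminomethyl compound thus returns a number in this assay, so removing this methyl strengthens inhibition by a margin beyond the usual scatter. The true size of the step stays unknown because compound 2 gives only a limit, not a number: the limit of > 200000 nM in this assay, at which 1 of the 4 values shown sits.

The compounds shown leave open whether the same change would have a similar effect with phenyl in place of 1H-pyrazol-1-yl. They also leave open how an ethyl group or an acetyl group on this nitrogen would compare with hydrogen and methyl.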